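Isopropylamino in Place of Isopropoxy: Expecting Compound 4

The compounds below may be only part of what the source reports. "The series", "measured", "known", "first", "only" and "open" are said of these compounds alone.

Compound 1 `CCS(=O)(=O)N1CCN(c2ccc(OCC3CCN(C(=O)OC(C)C)CC3)cn2)CC1` gives 1300 nM in a functional assay on CHO-K1 cells for agonist activity at Glucose-dependent insulinotropic receptor (Homo sapiens), read by a luciferase reporter, with a stated time of 5 h; on this read-out higher numbers stand for an effect only at larger amounts of compound and lower numbers for an effect already at smaller amounts.
Compound 2 `CCCS(=O)(=O)N1CCN(c2ccc(OCC3CCN(C(=O)OC(C)C)CC3)cn2)CC1` gives 300 nM in this assay.
Compound 3 `CC(C)OC(=O)N1CCC(COc2ccc(N3CCN(S(=O)(=O)c4cccnc4)CC3)nc2)CC1` gives 2000 nM in this assay.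

Compound 2 has the lowest number of the three in this assay. Its two neighbours are clearly separated from it: a 4.3-fold lower number from compound 1 to compound 2 (0.64 log units; beyond the scatter) and, going the other way, a 6.7-fold higher number from compound 2 to compound 3 (0.82 log units; beyond the scatter) both lie beyond the scatter. Compound 1 and compound 3 are not separated in this way, since a 1.5-fold higher number from compound 1 to compound 3 (0.19 log units; within the scatter) falls within the scatter.

Compound 4 `CCCS(=O)(=O)N1CCN(c2ccc(OCC3CCN(C(=O)NC(C)C)CC3)cn2)CC1` differs from compound 2 in a single place: isopropylamino in place of isopropoxy on a carbonyl carbon. None of the three measured steps touches this part of the molecule; all of them concern the group attached to the sulfonyl sulfur, on the far side of the shared core. Among the compounds with values here, there is therefore no measured step that bears on this change, and no basis in these numbers for expecting a shift in either direction. The change keeps the same number of heavy atoms and exchanges one acceptor for one donor.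

With nothing measured to push the expectation either way, compound 4 is estimated to give about 400 nM in this assay, plausibly between 150 nM and 1200 nM. That estimate corresponds to a 1.3-fold higher number from compound 2 to compound 4 (0.12 log units; within the scatter), a step expected to stay within the scatter.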

Compound 4, half-maximal effective concentration: 1000 nM
For compound 4 the middle estimate is 2.5-fold (0.40 log units) below the measured one; measured number inside the range.
By their numbers in this assay, from the lowest: compound 2; then compounds 4, 1 and 3 (each within the scatter of the next).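

Every earlier step concerned the group on the sulfonyl sulfur, so the group on the carbonyl carbon had not yet been tested. With propyl kept on the sulfonyl sulfur, this assay now shows that this second place also matters, since isopropylamino in place of isopropoxy gives a 3.3-fold higher number from compound 2 to compound 4 (0.52 log units; beyond the scatter) and so moves the number beyond the scatter, even though the two groups match in heavy-atom count and differ only in nitrogen for oxygen, with a hydrogen-bond donor entering and a hydrogen-bond acceptor leaving. No measurement is available to explain why this exchange raises the number, so the step records an effect and not its cause.

Going by these compounds, it remains open whether the same exchange would act alike with ethyl or pyridin-3-yl on the sulfonyl sulfur, since this single pair shows it only with propyl there. Dimethylamino on the carbonyl carbon, which has no amide hydrogen, and tert-butoxy, a larger relative of isopropoxy, would help to show whether that hydrogen or the shape of the alkyl part goes with the change.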